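tert-Butyl in Place of Methyl on the Core of Compound 3

The compounds below may be only part of what the source reports. "The series", "measured", "known", "first", "only" and "open" are said of these compounds alone.

Of the compounds shown here, three have so far been tested in an assay on isolated protein for inhibition of serine/threonine-protein kinase D2 (Homo sapiens), read by mobility shift assay, tested at 30 uM; on this read-out higher numbers stand for more inhibition at the one concentration tested (going by the name of the read-out) and lower numbers for less inhibition. Compound 1 `Cn1nc(N)c2c(=O)[nH]c(-c3ccccc3)cc21` gives 14% in this assay, and compound 2 `Cc1cc2c(c(N)nn2C)c(N2CCCCC2)n1` gives 16%. Compound 3 `Cc1cc2nn(-c3ccccc3)c(N)c2c(=O)[nH]1` gives -1% in this assay, the lowest of the three numbers: compound 1 stands above it by a gap beyond the usual scatter, and compound 2 stands further above it, again beyond the scatter. Compounds 1, 2 and 3 differ from one another in more than one place, so no single change can be tied to these gaps.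

Compound 4 `CC(C)(C)c1cc2nn(-c3ccccc3)c(N)c2c(=O)[nH]1` is the next compound to be measured in this assay. It differs from compound 3 in a single spot: tert-butyl in place of methyl on an aromatic carbon. Within the data shown here, nothing among the measured compounds shows what a change from methyl to tert-butyl does, so there is no basis for predicting a move in either direction. The step from compound 3 to compound 4 is therefore expected to be a number 4 percentage points higher from compound 3 to compound 4 (within the scatter), that is, no change beyond the scatter. Compound 4 is accordingly estimated at 3% in this assay, with a likely range from -10% to 18%.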

Compound 4, a percentage reported as inhibition, at one concentration (the size of the read-out at that concentration, not a potency): 15%
Compound 4: middle estimate off by 12 percentage points, on the low side; low and high end bracket the measured number.
By their numbers in this assay, from the lowest: compound 3; then compounds 1, 4 and 2 (each within the scatter of the next).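

In this assay, among these compounds, tert-butyl in place of methyl on this aromatic carbon, next to the ring nitrogen, gives a number 16 percentage points higher from compound 3 to compound 4 (beyond the scatter) and is the only step so far that ties a gap to a single change. This shows that the position is not indifferent to what sits on it: on this core, the larger of the two groups goes with more inhibition, although the step is modest and comes from a single concentration, so it says nothing about potency. No measurement shown gives a reason for this step.

With only methyl and tert-butyl shown at this spot, it remains open whether the number climbs gradually through groups of in-between size, such as ethyl or isopropyl, or whether only tert-butyl gives this rise. As far as these compounds go, it is also open whether a group of a different kind on the same carbon, such as an amine or a carboxylic acid, would raise the number, lower it or leave it unchanged.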